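Swapping the ring amine of a dithiocarbamate anilide

This account rests on a few compounds, and the source may have more. Where it says the series, first, only, none or still open, it means among the compounds named here.

Three compounds share one core: an anilide bearing a free amino group, joined through a benzyl linker to a dithiocarbamate whose amine end is varied. In a functional assay on A-375 cells (Homo sapiens) for antiproliferative activity, read by CCK-8 assay, with a stated time of 72 h, tested at 2 uM (a lower number here means a weaker effect, a higher number a stronger effect of the compound at the concentration tested), compound 1 `Nc1ccccc1NC(=O)c1ccc(CSC(=S)N2CCc3cc([N+](=O)[O-])ccc32)cc1` gives 16.9%, compound 2 `CC1CCCCN1C(=S)SCc1ccc(C(=O)Nc2ccccc2N)cc1` gives 42.5%, and compound 3 `Nc1ccccc1NC(=O)c1ccc(CSC(=S)N2CCN(Cc3ccccc3)CC2)cc1` gives 10.6%. Compound 2 stands highest of the three in this assay, with compound 1 the nearest and compound 3 the furthest, both gaps beyond the usual scatter.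

Compound 4 `Nc1ccccc1NC(=O)c1ccc(CSC(=S)N2CCCC2)cc1` has not yet been measured. It differs from compound 2 in one place: pyrrolidin-1-yl in place of 2-methylpiperidin-1-yl on a thiocarbonyl carbon. The amine end of the dithiocarbamate thus becomes a smaller, unsubstituted ring, while the rest of the molecule is unchanged.

Within the data shown here, no step between measured compounds is available to guide the size of this change, so the expectation rests on the three numbers alone. Compound 2, with its simple saturated ring amine, sits well above compound 1 and compound 3 in this assay; compound 4 keeps a simple saturated ring amine, so a modest drop, possibly within the scatter, is expected, a number 10.5 percentage points lower from compound 2 to compound 4 (beyond the scatter). Compound 4 is estimated at 32%, with a plausible range from 12% to 55%.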

Compound 4, a percentage reported as inhibition, at one concentration (the size of the read-out at that concentration, not a potency): 30.2%
The estimate for compound 4 lay 1.8 percentage points above the measured number, within the range that was stated.
By their numbers in this assay, from the lowest: compounds 3 and 1 (each within the scatter of the next); then compound 4; then compound 2.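

In this assay, among these compounds, pyrrolidin-1-yl in place of 2-methylpiperidin-1-yl on a thiocarbonyl carbon gives a number 12.3 percentage points lower from compound 2 to compound 4 (beyond the scatter), the only step here that can be read at a single place. It shows that the read-out responds to the amine end of the dithiocarbamate even when one saturated ring replaces another, yet compound 4 at 30.2% still stands above compound 1 at 16.9% and compound 3 at 10.6%. Nothing available explains why the number moves with this change.

The step alters ring size and removes the methyl group together, so the compounds shown cannot tell how much of it belongs to each. Piperidin-1-yl, which keeps the six-membered ring without the methyl group, would separate those two changes, and an open-chain diethylamino group would test whether a ring at this position matters at all.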